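This account rests on a few compounds, and the source may have more. Where it says the series, first, only, none or still open, it means among the compounds named here.

Series notes. Compound 1 `COc1ccc2c(=O)c(/C=C/C(=O)Nc3cccc(Cl)c3)coc2c1` carries the varied group on an amide-type nitrogen. In a functional assay on Huh-7 cells (Homo sapiens) for inhibition, read by MTT assay, with a stated time of 48 h (a higher number here means a weaker inhibitor, a lower number a stronger inhibitor), compound 1 gives only a limit, > 100000 nM. Compound 2 `COc1ccc2c(=O)c(/C=C/C(=O)NCc3cccc(F)c3)coc2c1` gives 10100 nM in this assay, and compound 3 `COc1ccc2c(=O)c(/C=C/C(=O)NCc3ccc(F)cc3)coc2c1` gives 21000 nM. The two steps from the aryl amide to benzyl amides are an at least 9.9-fold lower number from compound 1 to compound 2 (0.99 log units; beyond the scatter) and an at least 4.7-fold lower number from compound 1 to compound 3 (0.67 log units; beyond the scatter); between the benzyl amides, a 2.1-fold higher number from compound 2 to compound 3 (0.32 log units; beyond the scatter). Compound 1 thus stands at the limit of > 100000 nM in this assay, at which 1 of the 3 values shown sits, and every step from it is known only as a bound.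

Compound 4 `COc1ccc2c(=O)c(/C=C/C(=O)Nc3ccccc3OC)coc2c1` differs from compound 1 by 2-methoxyphenyl in place of 3-chlorophenyl on an amide-type nitrogen. Within the data shown here, no measured step swaps one aryl group for another directly on the amide-type nitrogen; both measured steps from compound 1 add a saturated chain carbon between nitrogen and ring. Going by these compounds, the size of the step for this change is unknown, and the expectation is that compound 4 stays close to where compound 1 stands, quite possibly again at the limit. Compound 4 is expected at 100000 nM, with a range of 25000 nM to 400000 nM. The step this estimate implies is a number no higher from compound 1 to compound 4 (the limit leaves the size open).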

Compound 4, half-maximal inhibitory concentration: 32300 nM
Compound 4: middle estimate off by 3.1-fold (0.49 log units), on the high side, and the stated range covers the measured number.
By their numbers in this assay, from the lowest: compound 2; then compounds 3 and 4 (each within the scatter of the next). At a limit, above all of these: compound 1.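

An aryl group directly on the amide-type nitrogen does not in itself leave a compound at the limit in this assay: an at least 3.0-fold lower number from compound 1 to compound 4 (0.49 log units; beyond the scatter). That step remains a bound, and its full size cannot be read: the limit of > 100000 nM in this assay, at which 1 of the 4 values shown sits. The saturated chain carbon is also not required to reach the level of compound 3, with a 1.5-fold higher number from compound 3 to compound 4 (0.19 log units; within the scatter), although a gap to the better benzyl amide remains, with a 3.2-fold higher number from compound 2 to compound 4 (0.50 log units; beyond the scatter).

Going by these compounds, the shift from 3-chlorophenyl to 2-methoxyphenyl changes both the substituent and its place on the ring, so the contribution of each stays open. Also open, on these data alone, is whether a longer chain on the amide-type nitrogen, or a carboxylic acid on its ring, would carry the series past compound 2.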